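The source may report more compounds than this note shows. Statements on the series, on what has been measured and on what is new or still open speak of the compounds shown alone.

Compound 2 `CC1=CC[C@@H]([C@@](C)(O)CCCC(C)(C)NC(=S)N/N=C\c2ccccc2)CC1` in a functional assay on UACC-62 cells (Homo sapiens) for cytotoxicity, read by sulforhodamine B assay (on this read-out lower numbers stand for stronger inhibition of growth and higher numbers for weaker inhibition of growth), gives 43800 nM, the highest of the two numbers in hand. Compound 3 `COc1ccc(/C=N\NC(=S)NC(C)(C)CCC[C@](C)(O)[C@@H]2CC=C(C)CC2)cc1` gives 22100 nM, and the step of a 2.0-fold lower number from compound 2 to compound 3 (0.30 log units; within the scatter) stays within the scatter. Compound 1 `CC1=CC[C@@H]([C@@](C)(O)CCCC(C)(C)NC(=S)NN)CC1` gives only a limit of the assay, > 100000 nM, not a number. Resting on (the limit of > 100000 nM in this assay, at which 1 of the 3 values shown sits), the steps of an at least 2.2-fold lower number from compound 1 to compound 2 (0.35 log units; beyond the scatter) and an at least 4.5-fold lower number from compound 1 to compound 3 (0.65 log units; beyond the scatter) concern the larger replacements on the amide-type nitrogen and are read as lower bounds only.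

Compound 4 `CC1=CC[C@@H]([C@@](C)(O)CCCC(C)(C)NC(=S)N/N=C\c2ccc(Cl)cc2)CC1` differs from compound 2 by chloro in place of hydrogen on an aromatic carbon. For the measured compounds named here, the one measured step that bears on a substituent of the aromatic ring, the methoxy step from compound 2 to compound 3, stayed within the scatter, so no step beyond the scatter is expected here: a 1.5-fold lower number from compound 2 to compound 4 (0.16 log units; within the scatter). Compound 4 is therefore estimated at 30000 nM, within 12000 nM to 80000 nM.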

Compound 4, concentration for total growth inhibition: 13800 nM
The estimate for compound 4 lay 2.2-fold (0.34 log units) above the measured number; low and high end bracket the measured number.
By their numbers in this assay, from the lowest: compounds 4, 3 and 2 (each within the scatter of the next, the first and the last beyond it). At a limit, above all of these: compound 1.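

For the compounds shown here, on the aromatic ring, chloro in place of hydrogen gives the first ring change that clears the scatter: a 3.2-fold lower number from compound 2 to compound 4 (0.50 log units; beyond the scatter). Chloro in place of methoxy gives a 1.6-fold lower number from compound 3 to compound 4 (0.20 log units; within the scatter), so these two substituents are not separated. Compound 1 gives only a limit of the assay, so an at least 7.2-fold lower number from compound 1 to compound 4 (0.86 log units; beyond the scatter) is a lower bound only: the limit of > 100000 nM in this assay, at which 1 of the 4 values shown sits.

Still open, going by these compounds, is how an amine or a carboxylic acid on the same aromatic carbon would compare with chloro. Also open, on these data alone, is whether chloro would give a similar step on another carbon of the ring.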